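3-Nitrophenyl to 3-chlorophenyl in the series

The source may report more compounds than this note shows. Statements on the series, on what has been measured and on what is new or still open speak of the compounds shown alone.

In a functional assay on HepG2 cells (Homo sapiens) for inhibition, read by MTT assay, with a stated time of 72 h (a higher number here means a weaker inhibitor, a lower number a stronger inhibitor), compound 1 (`Cc1cc2occ(-c3nc(-c4ccccc4)c(-c4ccccc4)n3-c3ccc([N+](=O)[O-])cc3)c(=O)c2cc1Cl`) gives 25000 nM and compound 2 (`Cc1cc2occ(-c3nc(-c4ccccc4)c(-c4ccccc4)n3-c3ccc(Cl)c(Cl)c3)c(=O)c2cc1Cl`) gives 12500 nM in the same series. Compound 3 (`Cc1cc2occ(-c3nc(-c4ccccc4)c(-c4ccccc4)n3-c3cccc([N+](=O)[O-])c3)c(=O)c2cc1Cl`) gives 25000 nM and stands level with compound 1, within the scatter of compound 2. Compound 4 (`Cc1cc2occ(-c3nc(-c4ccccc4)c(-c4ccccc4)n3-c3cccc(Cl)c3)c(=O)c2cc1Cl`) follows from compound 3 by chloro in place of nitro on an aromatic carbon, meta to a large group (chloro in place of nitro on an aromatic carbon), that is, 3-nitrophenyl to 3-chlorophenyl. Two measured steps on the same ring bear on this, no change at the digits printed from compound 1 to compound 3 (within the scatter) and a 2.0-fold higher number from compound 2 to compound 3 (0.30 log units; within the scatter), and neither leaves the scatter. On these steps, no change beyond the scatter is expected in this assay here. The expected step is a 1.5-fold lower number from compound 3 to compound 4 (0.17 log units; within the scatter) and no larger. Compound 4 is estimated at 17000 nM with an expected range (9000 nM to 32000 nM).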

Compound 4, half-maximal inhibitory concentration: 25000 nM
Estimate against measurement, compound 4: 1.5-fold (0.17 log units) below; low and high end bracket the measured number.
By their numbers in this assay, from the lowest: compounds 2, 1, 3 and 4 (each within the scatter of the next).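

In this assay chloro in place of nitro at this position gives no change at the digits printed from compound 3 to compound 4 (within the scatter) and so adds a swap of the group itself to the earlier swaps of the whole aryl ring. Hydrogen in place of chloro gives a 2.0-fold higher number from compound 2 to compound 4 (0.30 log units; within the scatter) and 3-chlorophenyl in place of 4-nitrophenyl gives no change at the digits printed from compound 1 to compound 4 (within the scatter) so all four compounds remain within the scatter of one another and no substituent tried here separates from the others. Nothing on hand accounts for this flat result.

Open, going by these compounds, is whether an amine, a carboxylic acid or a longer chain on this ring would give a step beyond the scatter. On these data alone, the role of the shared core and its two phenyl groups also stays open.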